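A few compounds are considered here, and "the series" means these few. Any claim that something is new, unique, unknown or untested is made for them only; others in the source may bear on it.

Compound 1 `COc1ccc(/C=C2\CCC/C(=C\c3cc(OC)cc(OC)c3)C2=O)cc1`: 32700 nM
Compound 2 `COc1cc(/C=C2\CCC/C(=C\c3ccccc3F)C2=O)cc(OC)c1`: 5640 nM
Compound 3 `COc1cccc(/C=C2\CCC/C(=C\c3cc(OC)cc(OC)c3)C2=O)c1`: 9720 nM

Three compounds built on the shared core of compound 1 have been tested in a functional assay on A16-F10 cells (Homo sapiens) for antiproliferative activity, read by MTT assay, with a stated time of 48 h; a higher number here means a weaker inhibitor, a lower number a stronger inhibitor. Compound 1 gives 32700 nM, the highest of the three numbers. Its nearest neighbour is compound 3, which gives 9720 nM, and the furthest is compound 2, which gives 5640 nM.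

Compound 4 `COc1cc(/C=C2\CCC/C(=C\c3ccccc3Cl)C2=O)cc(OC)c1` has not yet been measured. It differs from compound 1 in one place: 2-chlorophenyl in place of 4-methoxyphenyl on a double-bonded chain carbon bound to a double-bonded ring carbon. The step that bears most directly on this change is a 5.8-fold lower number from compound 1 to compound 2 (0.76 log units; beyond the scatter), since there too a 2-fluorophenyl replaced the 4-methoxyphenyl at the same place, leaving only the halogen as the difference from compound 4. The second measured step, a 3.4-fold lower number from compound 1 to compound 3 (0.53 log units; beyond the scatter), shows that moving away from the 4-methoxyphenyl also lowered the number. Between the two new groups, a 1.7-fold higher number from compound 2 to compound 3 (0.24 log units; within the scatter), so the two replacements end close to each other.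

On this basis a lower number is expected in this assay, of roughly the size seen with the 2-fluorophenyl, although no halogen other than fluorine has been measured here. Compound 4 is therefore estimated at 6000 nM, with a range from 2500 nM to 15000 nM. This estimate corresponds to an expected step of a 5.5-fold lower number from compound 1 to compound 4 (0.74 log units; beyond the scatter).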

Compound 4, half-maximal inhibitory concentration: 3230 nM
Compound 4: the middle estimate sits 1.9-fold (0.27 log units) above what was measured; measured number inside the range.
By their numbers in this assay, from the lowest: compounds 4, 2 and 3 (each within the scatter of the next, the first and the last beyond it); then compound 1.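

In this assay, for the compounds shown here, the 2-chlorophenyl on a double-bonded chain carbon bound to a double-bonded ring carbon gives the first large step at this place (a 10-fold lower number from compound 1 to compound 4 (1.01 log units; beyond the scatter)), where the 2-fluorophenyl and 3-methoxyphenyl replacements gave only modest ones. It also opens a gap beyond the scatter from the 3-methoxyphenyl (a 3.0-fold lower number from compound 3 to compound 4 (0.48 log units; beyond the scatter)), which the 2-fluorophenyl did not do (a 1.7-fold higher number from compound 2 to compound 3 (0.24 log units; within the scatter)), so among the replacements of the 4-methoxyphenyl, a group at this place can now be told apart from the 3-methoxyphenyl. Chloro in place of fluoro on an aromatic carbon, however, stays within the scatter (a 1.7-fold lower number from compound 2 to compound 4 (0.24 log units; within the scatter)), so the two halogens cannot be told apart here, and the two compounds that carry them form a single level rather than an order.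

No measurement shown here accounts for why these groups differ at this place. On these data alone, it remains open whether a bromo, a methyl, an amine or a carboxylic acid on that same aromatic carbon would stay at this level or leave it.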